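A few compounds are considered here, and "the series" means these few. Any claim that something is new, unique, unknown or untested is made for them only; others in the source may bear on it.

Working notes on the cyclopropylamino analogue. The series shares one core, carried by compound 1 `CNc1nc(N)nc2c1ncn2/C=C1/CC1(CO)CO`, compound 2 `CCOc1nc(N)nc2c1ncn2/C=C1/CC1(CO)CO` and compound 3 `CC(C)Nc1nc(N)nc2c1ncn2/C=C1/CC1(CO)CO`; the candidate is compound 4 `Nc1nc(NC2CC2)c2ncn(/C=C3/CC3(CO)CO)c2n1`. In an ADME assay on MOLT-3 cells (Homo sapiens) for cytotoxicity, with a stated time of 7 days (on this read-out higher numbers stand for lower toxicity in this test and lower numbers for higher toxicity in this test), compound 1 gives > 20000 nM, a limit of the assay rather than a number. In this assay compound 2 gives > 20000 nM, again only a limit. For compound 3 the entry in this assay reads "not determined" (no result reported), so no result exists there. For the measured compounds named here, compound 2 thus stands at the limit, as does compound 1, and the one recorded step, a step that the two limits leave unreadable from compound 1 to compound 2, cannot be sized. The change now considered is cyclopropylamino in place of ethoxy on an aromatic carbon. Going by the values given here, no measured step shares this change; the step from methylamino to ethoxy bears on it only in showing that the series sits at the limit, because of the limit of > 20000 nM in this assay, at which 2 of the 3 values shown sit. For compound 4 the expected step is a step that the limit leaves unreadable from compound 2 to compound 4, which means no step beyond the scatter, most likely reported once more as a limit. Compound 4 is estimated at 30000 nM, within 15000 nM to 100000 nM.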

Compound 4, half-maximal cytotoxic concentration: > 20000 nM
Compound 4 was reported as a limit (the forecaster's own chance of this, stated with the estimate: 85%); the middle value does not contradict the limit.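

Compound 4 joins compound 1 and compound 2 as a limit rather than a number, so no new step can be read among them: the limit of > 20000 nM in this assay, at which 3 of the 4 values shown sit.

The compounds shown leave open whether any group at this place on the shared core separates the series in this assay.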